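Amine nitrogen substituent change, compound 2 to compound 3

The compounds below may be only part of what the source reports. "The series", "measured", "known", "first", "only" and "open" are said of these compounds alone.

compound 1 `COc1cc(N)c(Cl)cc1NC(=O)C1CCN(C2CCCC2)CC1`: > 10 mg/kg (a limit of the assay, not a number)
compound 2 `CCCCCN1CCC(C(=O)Nc2cc(Cl)c(N)cc2OC)CC1`: > 10 mg/kg (a limit of the assay, not a number)

In a functional assay on the whole organism for antagonist activity, with Mus musculus as the target (on this read-out lower numbers stand for an effect already at smaller amounts and higher numbers for an effect only at larger amounts of compound), compound 1 gives > 10 mg/kg, which is a limit of the assay and not a number. Compound 2 gives > 10 mg/kg, likewise a limit. The step that the two limits leave unreadable from compound 1 to compound 2 therefore cannot be read. Compound 2 thus stands at the limit of > 10 mg/kg in this assay, at which 2 of the 2 values shown sit, the point shared by every value in hand.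

Compound 3 `COc1cc(N)c(Cl)cc1NC(=O)C1CCN(Cc2ccsc2)CC1` differs from compound 2 by thiophen-3-yl in place of butyl on a saturated chain carbon bound to an amine nitrogen in a ring. Among the compounds with values here, no measured step bears on this change: the one step in hand is cut at a different place and is unreadable, and nothing in the data gives a direction. Within the data shown here, the only anchor is that compound 2 sits at the limit. For compound 3 the expected step of a number no higher from compound 2 to compound 3 (the limit leaves the size open) is none beyond the scatter. Compound 3 is estimated at 10 mg/kg, from 3 mg/kg to 30 mg/kg, with a fair chance that this assay again reports only a limit.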

Compound 3, dose for half-maximal effect: 3.4 mg/kg
Estimate against measurement, compound 3: 2.9-fold (0.47 log units) above; the measured number falls inside the stated range.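

With (thiophen-3-yl)methyl on the amine nitrogen in a ring, the series gives its first reading under the limit in this assay, with thiophen-3-yl in place of butyl on a saturated chain carbon bound to an amine nitrogen in a ring giving an at least 2.9-fold lower number from compound 2 to compound 3 (0.46 log units; beyond the scatter). The same nitrogen carrying cyclopentyl instead leads to an at least 2.9-fold lower number from compound 1 to compound 3 (0.46 log units; beyond the scatter), so this position can move the read-out, and an open chain and a saturated ring both differ from the thiophene-bearing group. The step from compound 1 to compound 2 cannot be read, and the two readable steps give only a minimum size, because compound 1 and compound 2 both sit at a limit of the assay and not at a number: the limit of > 10 mg/kg in this assay, at which 2 of the 3 values shown sit.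

As far as these compounds go, whether the aromatic ring alone or its sulfur atom goes with the step stays open; benzyl or (furan-3-yl)methyl on the same nitrogen would separate the two. Also open, from the compounds shown here alone, is how the read-out responds to a longer link, as in 2-(thiophen-3-yl)ethyl.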